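Swapping a pyridine for a bromophenyl on the shared core

The source may hold more compounds than are shown below. What is called first, only, known or untested is meant among the compounds shown, and "the series" means these compounds.

Of the compounds shown here, three built on the same core have been tested in a functional assay on COS-7 cells (Chlorocebus aethiops) for inhibition, read by MTT assay; a higher number here means a weaker inhibitor, a lower number a stronger inhibitor. Compound 1, `Cc1ccc2c(c1)/C(=N/NC(=S)N/N=C/c1ccccn1)C(=O)N2`, carries a pyridin-2-yl group on the carbon with a double bond to nitrogen; in this assay compound 1 gives 2120 nM, the lowest of the two numbers measured. Compound 2, `O=C1Nc2ccc(Br)cc2/C1=N/NC(=S)N/N=C/c1ccc(Br)cc1`, gives 5180 nM, a higher number that lies beyond the usual scatter. Compound 3, `O=C1Nc2ccc(Br)cc2/C1=N/NC(=S)N/N=C/c1ccc2ccccc2c1`, gives > 50000 nM, which is a limit of this assay rather than a number, the one described as the limit of > 50000 nM in this assay, at which 1 of the 3 values shown sits.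

Compound 4, `Cc1ccc2c(c1)/C(=N/NC(=S)N/N=C/c1ccccc1Br)C(=O)N2`, is not yet measured. It differs from compound 1 in one place: 2-bromophenyl in place of pyridin-2-yl on a carbon with a double bond to nitrogen. Among the measured compounds shown here, no measured pair shows this change alone, so its size must be guessed from the spread seen so far. The change is expected to give the step of a 1.9-fold higher number from compound 1 to compound 4 (0.28 log units; within the scatter), a modest move toward a weaker inhibitor, since the other bromophenyl compounds sit higher than compound 1. Compound 4 is therefore estimated at 4000 nM, with a range from 1200 nM to 15000 nM.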

Compound 4, half-maximal inhibitory concentration: > 50000 nM
Compound 4 ended at the assay's limit (the forecaster's own chance of this, stated with the estimate: 5%); middle value at least 12-fold (1.09 log units) from the limit.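

In this assay compound 4 gives > 50000 nM, which is a limit of the assay and not a number. The group on the carbon with a double bond to nitrogen clearly matters in this series: putting 2-bromophenyl in place of pyridin-2-yl gives an at least 23-fold higher number from compound 1 to compound 4 (1.37 log units; beyond the scatter), the first single change shown at this place. How far beyond the limit compound 4 truly lies cannot be told, so this step marks only the smallest size the change could have: the limit of > 50000 nM in this assay, at which 2 of the 4 values shown sit.

The swap removes the ring nitrogen and adds the bromine in one move, so the compounds shown do not tell which of the two counts. An unsubstituted phenyl or a pyridin-3-yl group at this place would help to separate them.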